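The source may hold more compounds than are shown below. What is called first, only, known or untested is meant among the compounds shown, and "the series" means these compounds.

The shared core of compound 1 `NS(=O)(=O)c1ccc(Nc2nc(N/N=C/c3ccc(C(F)(F)F)cc3)nc(Nc3ccccc3)n2)cc1` carries a hydrazone arm, and in a functional assay on HT-29 cells (Homo sapiens) for inhibition, read by sulforhodamine B assay, with a stated time of 48 h (a lower number here means a stronger inhibitor of growth, a higher number a weaker inhibitor of growth), compound 1 gives 2440 nM. Compound 2 `Cc1nn(-c2ccccc2)cc1/C=N/Nc1nc(Nc2ccccc2)nc(Nc2ccc(S(N)(=O)=O)cc2)n1` differs only in the aryl group on that hydrazone carbon; in this assay compound 2 gives 2880 nM. Among the two measured compounds compound 2 has the highest number, with compound 1 nearest, but the step of a 1.2-fold higher number from compound 1 to compound 2 (0.07 log units; within the scatter) shows that the exchange of one aryl group for another at this position left the number essentially where it was.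

Compound 3 `NS(=O)(=O)c1ccc(Nc2nc(N/N=C/c3ccccn3)nc(Nc3ccccc3)n2)cc1` is not yet measured. It differs from compound 2 as follows: pyridin-2-yl in place of 3-methyl-1-phenyl-1H-pyrazol-4-yl on a carbon with a double bond to nitrogen. Among the measured compounds shown here, the only measured step that bears on this change is a 1.2-fold higher number from compound 1 to compound 2 (0.07 log units; within the scatter), which was within the scatter, so one aryl swap at the hydrazone carbon has so far made no difference that can be trusted. On that basis compound 3 is expected to give a number in this assay close to that of compound 2, with the expected step of a 1.0-fold higher number from compound 2 to compound 3 (0.02 log units; within the scatter) lying within the scatter. The estimate for compound 3 in this assay is therefore 3000 nM, with a range from 1200 nM to 7500 nM.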

Compound 3, concentration for 50% growth inhibition: 2150 nM
For compound 3 the middle estimate is 1.4-fold (0.14 log units) above the measured one; the measured number falls inside the stated range.
By their numbers in this assay, from the lowest: compounds 3, 1 and 2 (each within the scatter of the next).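

In this assay, the change from 3-methyl-1-phenyl-1H-pyrazol-4-yl to pyridin-2-yl on the carbon with a double bond to nitrogen gives a 1.3-fold lower number from compound 2 to compound 3 (0.13 log units; within the scatter) and takes the group from 12 heavy atoms to 6, yet the step stays within the scatter. Among the compounds shown here, the change from 4-(trifluoromethyl)phenyl to the same pyridin-2-yl gives a 1.1-fold lower number from compound 1 to compound 3 (0.05 log units; within the scatter) and is also within the scatter, so across these three compounds neither reducing the size of the group nor placing a ring nitrogen in a six-membered aromatic ring yields a difference that can be trusted, and no compound among them goes against this. No measurement at hand offers an explanation for this flat result.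

From the compounds shown here alone, all three groups at this carbon are aromatic rings, so it remains open whether a cyclohexyl ring, a longer alkyl chain, or an aryl group bearing a carboxylic acid or an amine would move the number beyond the scatter. The rest of the shared core is the same in all three compounds, so they say nothing about changes elsewhere, such as at the sulfonamide.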